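The source may report more compounds than this note shows. Statements on the series, on what has been measured and on what is new or still open speak of the compounds shown alone.

Compound 1 `CCOC(=O)CNc1nc(-n2nc(-c3ccccn3)nc2N)c2cc(OC)c(OC)cc2n1`: > 40000 nM in an assay on MCF7 cells for inhibition of Serine-protein kinase ATM (Homo sapiens), read by immunofluorescence, with a stated time of 1 h; a lower number here means a stronger inhibitor, a higher number a weaker inhibitor
Compound 2 `COc1cc2ncnc(-n3cnc(-c4ccccn4)n3)c2cc1OC`: 5300 nM
Compound 3 `COc1cc2ncnc(-n3nc(-c4ccccn4)nc3N)c2cc1OCCCNC(=O)CN1C[C@@H](C)O[C@@H](C)C1`: 1700 nM

The value given for compound 1 is a limit of this assay, not a number; the reading sits at the limit of > 40000 nM in this assay, at which 1 of the 3 values shown sits. Among the two numbers that were actually obtained, compound 3 has the lowest, with compound 2 the nearest and its number higher by a gap that lies beyond the usual scatter. On this small set, compound 3 therefore stands as the strongest inhibitor among the compounds that gave a number.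

Compound 4 `COc1cc2ncnc(-n3nc(-c4ccccn4)nc3N)c2cc1OCCCNC(=O)C(F)(F)F` has not yet been measured in this assay. It differs from compound 3 in one place only: trifluoromethyl in place of (2,6-dimethylmorpholin-4-yl)methyl on a carbonyl carbon. The remaining part of the molecule, including the shared core and the chain carrying the amide, stays the same.

Within the data shown here, no step between two measured compounds resembles this change, so the expectation for compound 4 rests on compound 3 alone. The step from compound 3 to compound 4 is expected to be a 1.8-fold higher number from compound 3 to compound 4 (0.25 log units; within the scatter), a modest weakening that may well fall within the scatter. Compound 4 is thus estimated at 3000 nM in this assay, with a plausible range from 800 nM to 12000 nM.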

Compound 4, half-maximal inhibitory concentration: 2900 nM
For compound 4 the middle estimate is 1.0-fold (0.01 log units) above the measured one, within the range that was stated.
By their numbers in this assay, from the lowest: compounds 3, 4 and 2 (each within the scatter of the next, the first and the last beyond it). At a limit, above all of these: compound 1.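

In this assay, the exchange of (2,6-dimethylmorpholin-4-yl)methyl for trifluoromethyl on the carbonyl carbon is a step of a 1.7-fold higher number from compound 3 to compound 4 (0.23 log units; within the scatter), so compound 3 and compound 4 cannot be told apart in this pair. This position can therefore carry either a group of 9 heavy atoms, with a six-membered non-aromatic ring and 2 defined stereocentres, or a group of 4 heavy atoms with no ring, without a reading beyond the usual scatter; in this one pair, neither the ring nor the stereocentres are needed to reach this level of inhibition. Nothing measured here explains why the two groups read so alike.

From the compounds shown here alone, two end groups are a narrow sample of this position, so it remains open whether a primary amine or a carboxylic acid in the same place would leave the number unchanged or move it beyond the scatter. Among these compounds, also open is what the chain carrying the amide contributes on its own, and whether a longer chain would change the reading, as compound 3 and compound 4 share the same chain and no one-place step tests it.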